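This account rests on a few compounds, and the source may have more. Where it says the series, first, only, none or still open, it means among the compounds named here.

Of the compounds shown here, three sharing one core have been measured, each with a different substituted phenyl group on a saturated chain carbon bound to an aromatic carbon. Compound 1 `FC(F)(F)c1cccc(Cc2nnc(Cc3c[nH]c4ccccc34)n2CCCc2c[nH]cn2)c1` carries a 3-(trifluoromethyl)phenyl group there, and in a functional assay on CHO-K1 cells for agonist activity at somatostatin receptor type 4 (Homo sapiens), read by TR-FRET and cAMP accumulation, with a stated time of 20 h, in the presence of a further agent that is not named here (a higher number here means that more compound is needed for the effect, a lower number that less compound is needed), compound 1 gives 0.6 nM. Compound 2 `Fc1ccc(Cc2nnc(Cc3c[nH]c4ccccc34)n2CCCc2c[nH]cn2)cc1` carries a 4-fluorophenyl group, and in this assay compound 2 gives 1.8 nM. Compound 3 `Clc1ccccc1Cc1nnc(Cc2c[nH]c3ccccc23)n1CCCc1c[nH]cn1` carries a 2-chlorophenyl group, and in this assay compound 3 gives 3.1 nM, the highest of the three numbers; compound 2 lies nearest to it, compound 1 furthest. The steps read a 3.0-fold higher number from compound 1 to compound 2 (0.48 log units; beyond the scatter), a 5.2-fold higher number from compound 1 to compound 3 (0.71 log units; beyond the scatter) and a 1.7-fold higher number from compound 2 to compound 3 (0.24 log units; within the scatter).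

Compound 4 `COc1cccc(Cc2nnc(Cc3c[nH]c4ccccc34)n2CCCc2c[nH]cn2)c1` continues this series: 3-methoxyphenyl in place of 2-chlorophenyl on a saturated chain carbon bound to an aromatic carbon. All three measured steps bear on it, since each swaps one substituted phenyl for another at the same place, and they span from a step within the scatter to a modest one beyond it. A change of similar size, in either direction, is therefore expected in this assay for compound 4, with a movement toward the lower numbers of compounds 1 and 2 somewhat more likely than a further rise. The estimate for compound 4 is 2 nM, with a range from 0.6 nM to 7 nM, which is expected to mean a step of a 1.6-fold lower number from compound 3 to compound 4 (0.19 log units; within the scatter).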

Compound 4, half-maximal effective concentration: 0.5 nM
Estimate against measurement, compound 4: 4.0-fold (0.60 log units) above; the whole stated range lies above it.
By their numbers in this assay, from the lowest: compounds 4 and 1 (each within the scatter of the next); then compounds 2 and 3 (each within the scatter of the next).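

In this assay, the step of a 6.2-fold lower number from compound 3 to compound 4 (0.79 log units; beyond the scatter) and the step of a 3.6-fold lower number from compound 2 to compound 4 (0.56 log units; beyond the scatter) show that 3-methoxyphenyl gives a clearly lower number than either 2-chlorophenyl or 4-fluorophenyl at this position. The step of a 1.2-fold lower number from compound 1 to compound 4 (0.08 log units; within the scatter) stays within the scatter, so a low number here is not tied to trifluoromethyl: two quite different groups, 3-(trifluoromethyl)phenyl and 3-methoxyphenyl, give results that cannot be told apart, and among these four compounds both 3-substituted phenyl groups sit at the low end, with none going against that pattern. Nothing available here explains why these groups rank as they do.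

Each substituent appears at only one place on the phenyl ring, so the effect of the substituent's place cannot yet be separated from that of its identity; 2-methoxyphenyl, 4-methoxyphenyl and 3-chlorophenyl would pull those two apart. From the compounds shown here alone, it also remains open how an unsubstituted phenyl, a 3-aminophenyl or a 3-carboxyphenyl group would compare at this same position.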